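Chain extension on the acrylamide of the methylated analogue

The source may report more compounds than this note shows. Statements on the series, on what has been measured and on what is new or still open speak of the compounds shown alone.

Compound 1 `C=CC(=O)Nc1cc(Nc2nccc(-c3cn(C)c4ccc(F)cc34)n2)c(OC)cc1N(C)CCN(C)C` is the reference point of the series: in a functional assay on A549 cells (Homo sapiens) for antiproliferative activity, read by MTT assay, with a stated time of 72 h (on this read-out higher numbers stand for weaker inhibition and lower numbers for stronger inhibition), compound 1 gives 329 nM. Compound 2 `CCC/C=C\C(=O)Nc1cc(Nc2nccc(-c3cn(C)c4ccc(F)cc34)n2)c(OC)cc1N(C)CCN(C)C` carries a pent-1-en-1-yl in place of the vinyl, and compound 2 gives 1030 nM. Compound 3 `C=CC(=O)Nc1cc(Nc2nc(C)cc(-c3cn(C)c4ccc(F)cc34)n2)c(OC)cc1N(C)CCN(C)C` instead carries a methyl in place of hydrogen on an aromatic carbon of the shared core, and compound 3 gives 1490 nM. On these numbers compound 3 has the highest value of the three; its gap to compound 2 lies within the scatter, its gap to compound 1 does not, as a 4.5-fold higher number from compound 1 to compound 3 (0.66 log units; beyond the scatter) shows.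

Compound 4 `CCC/C=C\C(=O)Nc1cc(Nc2nc(C)cc(-c3cn(C)c4ccc(F)cc34)n2)c(OC)cc1N(C)CCN(C)C` combines both alterations; the step from compound 3 is pent-1-en-1-yl in place of vinyl on a carbonyl carbon. Within the data shown here, the one measured step that bears on it is the same replacement made on compound 1, which gave a 3.1-fold higher number from compound 1 to compound 2 (0.50 log units; beyond the scatter). A step of comparable size and direction is therefore expected here, a 3.0-fold higher number from compound 3 to compound 4 (0.48 log units; beyond the scatter), a modest rise beyond the scatter. Compound 4 is estimated at 4500 nM, with a range from 2000 nM to 10000 nM.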

Compound 4, half-maximal inhibitory concentration: 13300 nM
The estimate for compound 4 lay 3.0-fold (0.47 log units) below the measured number; measured number outside the range, above it.
By their numbers in this assay, from the lowest: compound 1; then compounds 2 and 3 (each within the scatter of the next); then compound 4.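

The two replacements do not simply add up in this assay: pent-1-en-1-yl in place of vinyl on a carbonyl carbon costs more on the methylated core (an 8.9-fold higher number from compound 3 to compound 4 (0.95 log units; beyond the scatter)), and methyl in place of hydrogen on an aromatic carbon costs more once pent-1-en-1-yl is present (a 13-fold higher number from compound 2 to compound 4 (1.11 log units; beyond the scatter)). The size of the step at the carbonyl carbon therefore depends on the core: the same change on two cores in this assay, a 3.1-fold higher number (0.50 log units; beyond the scatter) from compound 1 to compound 2 and an 8.9-fold higher number (0.95 log units; beyond the scatter) from compound 3 to compound 4, 2.9-fold (0.46 log units) apart, beyond the scatter of two such steps. Likewise, the size of the step at the aromatic carbon depends on what the carbonyl carbon carries: the same change on two cores in this assay, a 4.5-fold higher number (0.66 log units; beyond the scatter) from compound 1 to compound 3 and a 13-fold higher number (1.11 log units; beyond the scatter) from compound 2 to compound 4, 2.9-fold (0.46 log units) apart, beyond the scatter of two such steps.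

As far as these compounds go, whether the larger step follows chain length remains open, as does whether a shorter prop-1-en-1-yl would show the same dependence on the methylated core. Also open, from the compounds shown here alone, is how an amine carried on that chain, or an ethyl in place of the methyl on the aromatic carbon, would compare.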